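This account rests on a few compounds, and the source may have more. Where it says the series, first, only, none or still open, it means among the compounds named here.

Going by the values given here, compound 1 `COc1ccc(C2=NN(C3=NC(=O)/C(=C4\C(=O)Nc5ccc(Br)cc54)S3)C(c3ccc(OC)cc3)C2)cc1` is one of two compounds measured in a functional assay on cells (Cancer cell lines, Homo sapiens) for cytotoxicity, read by sulforhodamine B assay, with a stated time of 48 h (on this read-out higher numbers stand for weaker inhibition of growth and lower numbers for stronger inhibition of growth), where compound 1 gives 430 nM. Among the compounds with values here, its only measured neighbour, compound 2 `COc1ccc(C2=NN(C3=NC(=O)/C(=C4\C(=O)Nc5ccc(Cl)cc54)S3)C(c3ccc(OC)cc3)C2)cc1`, gives 440 nM in this assay, and the step of a 1.0-fold higher number from compound 1 to compound 2 (0.01 log units; within the scatter) leaves the two compounds within the scatter of each other, so compound 1 stands alongside compound 2 rather than apart from it.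

Compound 3 `COc1ccc(C2CC(c3ccc4ccccc4c3)=NN2C2=NC(=O)/C(=C3\C(=O)Nc4ccc(Br)cc43)S2)cc1` has not yet been measured in this assay. It differs from compound 1 in one place: naphthalen-2-yl in place of 4-methoxyphenyl on a carbon with a double bond to nitrogen. Within the data shown here, no measured step touches this position. Among the measured compounds shown here, the single step that has been measured, a 1.0-fold higher number from compound 1 to compound 2 (0.01 log units; within the scatter), swaps one halogen for another on an aromatic carbon of the shared core and is within the scatter, so it offers no guidance on what a change at the carbon with a double bond to nitrogen does. The expectation for compound 3 therefore rests on the general observation that the core has so far tolerated a change without moving the number, and the expected step is a 1.2-fold higher number from compound 1 to compound 3 (0.07 log units; within the scatter) with a wide range. On that basis compound 3 is estimated at 500 nM, between 150 nM and 1700 nM.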

Compound 3, concentration for total growth inhibition: 220 nM
Estimate against measurement, compound 3: 2.3-fold (0.36 log units) above; low and high end bracket the measured number.
By their numbers in this assay, from the lowest: compounds 3, 1 and 2 (each within the scatter of the next).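

Going by these compounds alone, the step at the carbon with a double bond to nitrogen is the first measured change at this position, and in this assay replacing 4-methoxyphenyl with naphthalen-2-yl gives a 2.0-fold lower number from compound 1 to compound 3 (0.29 log units; within the scatter). This shows that the position can carry a group with 2 six-membered aromatic rings of carbon only and no hydrogen-bond acceptor while compound 3 stays within the scatter of compound 1, so neither the second ring nor the absence of the methoxy oxygen produces a step that can be told apart from repeat variation. No supporting measurement bears on how this swap acts on growth inhibition, and the result stands here as an observation only.

With a single replacement shown at this position, the compounds leave open whether a small methyl group, an amine or a carboxylic acid in place of the aromatic group would keep the number in the same range. They also leave open whether the 4-methoxyphenyl group on the other ring atom can be exchanged for a pyridine or a plain phenyl ring with the same outcome.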